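This account rests on a few compounds, and the source may have more. Where it says the series, first, only, none or still open, it means among the compounds named here.

Compound 1, with the structure `Cc1cccc(Cn2c(CN3CCN(C(=O)c4cccnc4)CC3)nc3ccccc32)c1`, and compound 2, with the structure `CCCCn1c(CN2CCN(C(=O)C3CC3)CC2)nc2ccccc21`, share a common core carrying a piperazine amide. In an assay on isolated protein for inhibition of aldehyde dehydrogenase 1A1 (Homo sapiens), read by spectrophotometry, tested at 10 uM (on this read-out higher numbers stand for more inhibition at the one concentration tested (going by the name of the read-out) and lower numbers for less inhibition), compound 1 gives 24.5%, the higher of the two numbers in hand, while compound 2 gives 18.2%; the gap between these two values lies within the usual scatter, so the two compounds cannot be ranked against each other on these data.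

Compound 3, with the structure `Cc1cccc(Cn2c(CN3CCN(C(=O)C(C)C)CC3)nc3ccccc32)c1`, has not yet been measured. It differs from compound 1 at a single place: isopropyl in place of pyridin-3-yl on a carbonyl carbon. A pyridin-3-yl leaves and an isopropyl enters on a carbonyl carbon whose other neighbour is an amide-type nitrogen in a ring. Going by the values given here, no measured pair of compounds shows what such an exchange does, so the step expected from compound 1 to compound 3, a number 4.5 percentage points lower from compound 1 to compound 3 (within the scatter), is estimated as small and not beyond the scatter, in either direction. For compound 3 in this assay the estimated inhibition is 20%, expected to fall between 6% and 36%.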

Compound 3, a percentage reported as inhibition, at one concentration (the size of the read-out at that concentration, not a potency): 87.2%
Estimate against measurement, compound 3: 67.2 percentage points below, outside the stated range (above it).
By their numbers in this assay, from the lowest: compounds 2 and 1 (each within the scatter of the next); then compound 3.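

In this assay, the group on this carbonyl carbon turns out to matter greatly: with the rest of the structure unchanged, isopropyl in place of pyridin-3-yl gives a number 62.7 percentage points higher from compound 1 to compound 3 (beyond the scatter). The earlier compounds shown here offered no pair differing in one place, so they could not show that this single position can carry so large a change in inhibition at the tested concentration. Nothing in hand explains why this exchange has such a large effect.

The compounds shown leave open whether the higher number is particular to isopropyl or would also appear with other groups on the same carbonyl carbon, such as tert-butyl or a longer chain. A phenyl group there would help show whether the lower number goes with the six-membered aromatic ring itself or with its nitrogen.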